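Moving the Nitro Group Around the Ring

A few compounds are considered here, and "the series" means these few. Any claim that something is new, unique, unknown or untested is made for them only; others in the source may bear on it.

Compound 1 `COc1cc(/C=C2\CCC/C(=C\c3ccccc3[N+](=O)[O-])C2=O)cc(OC)c1OC` is the strongest of the three measured compounds in a functional assay on L1210 cells (Mus musculus) for cytotoxicity, with a stated time of 48 h (a higher number here means a weaker inhibitor, a lower number a stronger inhibitor), where compound 1 gives 1520 nM. The other two compounds carry a fluorophenyl group on the far side of the shared core: compound 2 `O=C1/C(=C/c2ccc(F)cc2)CCC/C1=C\c1ccc([N+](=O)[O-])cc1` gives 26800 nM in this assay, and compound 3 `O=C1/C(=C/c2ccc(F)cc2)CCC/C1=C\c1cccc([N+](=O)[O-])c1` gives 16300 nM. Both of these numbers lie well above that of compound 1, with compound 3 the nearer of the two and compound 2 the further.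

The unmeasured compound 4 `COc1cc(/C=C2\CCC/C(=C\c3ccc([N+](=O)[O-])cc3)C2=O)cc(OC)c1OC` keeps everything in compound 1 except the nitro group's position: 4-nitrophenyl in place of 2-nitrophenyl on a double-bonded chain carbon bound to a double-bonded ring carbon. Within the data shown here, no pair of measured compounds differs only in this way, so the size of the step cannot be read from the data. Compounds 2 and 3 show that the two other nitro positions on the fluorophenyl side both give weak cytotoxicity, and the step from compound 1 to compound 4 is expected to be a moderate loss, a 2.3-fold higher number from compound 1 to compound 4 (0.36 log units; beyond the scatter). Compound 4 is therefore estimated at 3500 nM, within a range from 1200 nM to 12000 nM.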

Compound 4, half-maximal inhibitory concentration: 6970 nM
The estimate for compound 4 lay 2.0-fold (0.30 log units) below the measured number; the range from low to high includes it.
By their numbers in this assay, from the lowest: compound 1; then compound 4; then compounds 3 and 2 (each within the scatter of the next).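

With everything else in the molecule held fixed, this assay responds to the position of the nitro group alone: 4-nitrophenyl in place of 2-nitrophenyl gives a 4.6-fold higher number from compound 1 to compound 4 (0.66 log units; beyond the scatter). The two groups have the same atoms and the same counts of rings, double bonds and hydrogen-bond acceptors, so a change in how those atoms are joined is enough to move the number beyond the scatter. Nothing available here explains why the number moves in this direction.

Among these compounds, compounds 2 and 3 differ from compound 1 and compound 4 in more than one place, so no step to them can be read. On these data alone, it also remains open whether an amine or a carboxylic acid in place of the nitro group would give a lower or a higher number than either nitro compound.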